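The source may report more compounds than this note shows. Statements on the series, on what has been measured and on what is new or still open speak of the compounds shown alone.

Measured compounds:
- compound 1 `CNc1nc(-c2ccccc2)nc2c1nnn2Cc1ccccc1Cl`: 191000000 nM
- compound 2 `CNc1nc(-c2ccccc2)nc2c1nnn2Cc1ccccc1F`: 25000000 nM
- compound 3 `FC(F)(F)c1ccccc1Cn1nnc2c(NC3CCCC3)nc(-c3ccccc3)nc21`: 600000 nM

All three numbers come from an assay on isolated protein for binding affinity to adenosine receptor A1 (Bos taurus); on this read-out higher numbers stand for weaker inhibition and lower numbers for stronger inhibition. Compound 1 stands at the highest number of the three; compound 2 gives 25000000 nM, and compound 3 gives 600000 nM, far lower still. For the measured compounds named here, the only single-point step among the measured compounds is a 7.6-fold lower number from compound 1 to compound 2 (0.88 log units; beyond the scatter), which concerns the group on the benzyl ring, not the amino substituent.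

Compound 4 `CCCCCCNc1nc(-c2ccccc2)nc2c1nnn2Cc1ccccc1Cl` differs from compound 1 by pentyl in place of hydrogen on a saturated chain carbon bound to a nitrogen on an aromatic ring. Going by the values given here, no measured step touches this position on its own. Compound 3 carries a cyclopentylamino group in place of methylamino together with a trifluoromethyl group in place of chloro, and its number is far below that of compound 1. With two changes at once, the share that belongs to the larger amino group cannot be separated from the share that belongs to the other change. The step from compound 1 to compound 2 does not bear on the chain change directly. The expectation is therefore tentative: a lower number for compound 4, in the direction that the pair of compound 1 and compound 3 hints at, estimated as a 13-fold lower number from compound 1 to compound 4 (1.10 log units; beyond the scatter). Compound 4 is expected to give about 15000000 nM, with a range from 2000000 nM to 120000000 nM.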

Compound 4, inhibition constant: 31000000 nM
Compound 4: middle estimate off by 2.1-fold (0.32 log units), on the low side, within the range that was stated.
By their numbers in this assay, from the lowest: compound 3; then compounds 2 and 4 (each within the scatter of the next); then compound 1.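

For the compounds shown here, with nothing else changed, going from methylamino to hexylamino gives a 6.2-fold lower number from compound 1 to compound 4 (0.79 log units; beyond the scatter) in this assay, and this is the first reading of the amino substituent on its own. The number at this position therefore responds to what the nitrogen carries: adding pentyl on the saturated chain carbon moves it down, in a step beyond the scatter, while the chloro group stays fixed. No measured information accounts for this step.

From the compounds shown here alone, with a single step at this position, it remains open whether the number falls steadily as the chain grows, or whether a propyl chain, a longer octyl chain or a hexyl chain ending in a hydroxyl or an amine would give a different result. Going by these compounds, it is also open whether the same step holds when fluoro or trifluoromethyl replaces chloro, and how a cyclopentylamino group would compare with hexylamino on the chloro compound.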